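Notes on methoxy in place of chloro

The compounds below may be only part of what the source reports. "The series", "measured", "known", "first", "only" and "open" are said of these compounds alone.

- compound 1 `CCN(CC)CN1C(=O)/C(=N/NC(=S)Nc2ccc(Cl)cc2)c2ccccc21` gives 11000 nM
- compound 2 `CCN(CC)CN1C(=O)/C(=N/NC(N)=S)c2cc(Cl)ccc21` gives 148000 nM

Both values come from a functional assay on L1210 cells (Mus musculus) for inhibition, read by cell counting, with a stated time of 48 h; on this read-out lower numbers stand for stronger inhibition and higher numbers for weaker inhibition. Compound 1 holds the lower of the two numbers, at 11000 nM, and its gap to compound 2 at 148000 nM lies beyond the scatter. Within the data shown here, the series so far contains no measured step that differs in one place, so no direct precedent exists for the next change.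

Compound 3 `CCN(CC)CN1C(=O)/C(=N/NC(=S)Nc2ccc(OC)cc2)c2ccccc21` keeps the core of compound 1 and alters one substituent: methoxy in place of chloro on an aromatic carbon. This is methoxy in place of chloro on an aromatic carbon, para to a large group, turning 4-chlorophenyl into 4-methoxyphenyl. The rest of the structure stays the same, so compound 1 at 11000 nM serves as the only anchor for the expectation. Among the measured compounds shown here, with no measured precedent, no step beyond the scatter is expected in this assay, and only a slight lean toward a higher number is assumed. The estimated 1.3-fold higher number from compound 1 to compound 3 (0.10 log units; within the scatter) is therefore small. Compound 3 is expected at 14000 nM, with an estimated range of 5000 nM to 40000 nM.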

Compound 3, half-maximal inhibitory concentration: 2400 nM
Compound 3: the middle estimate sits 5.8-fold (0.77 log units) above what was measured; the measured number lies below the stated range.
By their numbers in this assay, from the lowest: compound 3; then compound 1; then compound 2.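

In this assay, among these compounds, replacing 4-chlorophenyl with 4-methoxyphenyl gives a 4.6-fold lower number from compound 1 to compound 3 (0.66 log units; beyond the scatter), the first one-place step and one that lies beyond the scatter. The group para to a large group on this aromatic ring therefore affects the read-out, and with the rest of the structure unchanged, the step can be assigned to this single exchange of chloro for methoxy, in the direction of stronger inhibition. Nothing measured on this series bears on why the exchange has this effect.

The compounds shown leave open whether the lower number is particular to methoxy or extends to other groups at this place, such as ethoxy, hydroxyl or dimethylamino. Also open, from the compounds shown here alone, is where a plain phenyl, with hydrogen in place of chloro or methoxy, would fall relative to compound 1 and compound 3, so a single step cannot yet tell whether methoxy lowers the number from a neutral baseline or chloro raises it.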